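Swapping methyl for chloro on the aryl ring

The compounds below may be only part of what the source reports. "The series", "measured", "known", "first", "only" and "open" are said of these compounds alone.

Of the compounds shown here, three have been measured in a functional assay on NIH3T3 cells for agonist activity at Urotensin-2 receptor (Homo sapiens), with a stated time of 5 days; a higher number here means that more compound is needed for the effect, a lower number that less compound is needed. Compound 1, with the structure `COc1ccc(CCC(=O)NC(CCN(C)C)c2ccc3ccccc3c2)cc1`, gives 1410 nM. Compound 2, with the structure `COc1ccc(/C=C/C(=O)NC(CCN(C)C)c2ccc(C)cc2)cc1`, gives 2000 nM, the highest of the three numbers, although its gap to compound 1 lies within the usual scatter of this assay. Compound 3, with the structure `CN(C)CCC(NC(=O)C#Cc1ccccc1)c1ccc(Cl)cc1`, gives 398 nM, a number well below that of compound 2 and beyond the scatter; compound 3 differs from compound 2 in more than one place, so no single change can be read from that pair.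

The new compound 4 has the structure `COc1ccc(/C=C/C(=O)NC(CCN(C)C)c2ccc(Cl)cc2)cc1`. It differs from compound 2 by a single change: chloro in place of methyl on an aromatic carbon. For the measured compounds named here, no pair among the measured compounds shows this change on its own, so no measured step exists for it. Compound 3 carries the same chloro group and sits lowest, which hints at, but does not establish, a lower number. Compound 4 is therefore expected to show a small step downward, a 2.0-fold lower number from compound 2 to compound 4 (0.30 log units; within the scatter), that may or may not exceed the scatter. The estimate for compound 4 in this assay is 1000 nM, with a range from 300 nM to 3000 nM.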

Compound 4, half-maximal effective concentration: 513 nM
Compound 4: the middle estimate sits 1.9-fold (0.29 log units) above what was measured; the range from low to high includes it.
By their numbers in this assay, from the lowest: compounds 3 and 4 (each within the scatter of the next); then compounds 1 and 2 (each within the scatter of the next).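

For the compounds shown here, this is the first pair in which chloro replaces methyl with nothing else altered, and in this assay the swap gives a 3.9-fold lower number from compound 2 to compound 4 (0.59 log units; beyond the scatter) at this aromatic carbon, para to a large group. On this core, then, going from 4-methylphenyl to 4-chlorophenyl lowers the amount of compound needed for the effect. The two groups have the same heavy-atom count, and neither has a hydrogen-bond donor or acceptor, so those counts do not distinguish them.

Going by these compounds, whether bromo, trifluoromethyl or an amine at the same position would lower the number further remains open, as does whether the swap gives a similar step on other cores. Nothing available here explains why chloro gives the lower number.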